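This account rests on a few compounds, and the source may have more. Where it says the series, first, only, none or still open, it means among the compounds named here.

Measured so far in a functional assay on RAW264.7 cells (Mus musculus) for inhibition, read by Griess assay, with stated times of 1 h and 24 h (on this read-out lower numbers stand for stronger inhibition and higher numbers for weaker inhibition), on the shared core:
- compound 1 `COc1ccc(C(O)C2OC(=O)c3c(OC)cc(OC)cc32)cc1` gives > 10000 nM (a limit)
- compound 2 `COCCOc1ccc(C(O)C2OC(=O)c3c(OC)cc(OC)cc32)cc1` gives > 10000 nM (a limit)
- compound 3 `COc1cc(OC)c2c(c1)C(C(O)c1ccc(OCc3ccc(F)cc3)cc1)OC2=O` gives 760 nM (a number)

For the measured compounds named here, compound 3 gives 760 nM and is the only compound here with a number, so it stands as the most active of the three. Compound 1 and compound 2 carry no number (the limit of > 10000 nM in this assay, at which 2 of the 3 values shown sit).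

Compound 4 `COc1cc(OC)c2c(c1)C(C(O)c1ccc(OCc3ccc(OC(F)F)cc3)cc1)OC2=O` differs from compound 3 at one place (difluoromethoxy in place of fluoro on an aromatic carbon). Difluoromethoxy stands in place of fluoro on an aromatic carbon, para to a large group, so 4-fluorobenzyl becomes 4-(difluoromethoxy)benzyl.

Going by the values given here, two measured steps bear on this, both large, and both bring in the 4-fluorophenyl (an at least 13-fold lower number from compound 1 to compound 3 (1.11 log units; beyond the scatter)) and (an at least 13-fold lower number from compound 2 to compound 3 (1.11 log units; beyond the scatter)). The third step cannot be read (a step that the two limits leave unreadable from compound 1 to compound 2). Among the compounds with values here, compound 4 keeps the benzyl group that came with the step to compound 3 (an at least 13-fold lower number from compound 1 to compound 3 (1.11 log units; beyond the scatter)), and no measured step changes the substituent on that ring. On these data alone, the size of this change therefore remains open, and no large loss or gain is expected.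

The expected change is a 1.1-fold higher number from compound 3 to compound 4 (0.02 log units; within the scatter) (an estimate, with no shift beyond the scatter expected). In this assay compound 4 is estimated at 800 nM with an expected range from 250 nM to 3000 nM (both ends estimated).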

Compound 4, half-maximal inhibitory concentration: 5030 nM
The estimate for compound 4 lay 6.3-fold (0.80 log units) below the measured number; measured number outside the range, above it.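

In this assay, the substituent on the aromatic carbon para to a large group has a readable effect: this is the first step shown at this place, and putting difluoromethoxy in place of fluoro moves the number beyond the scatter (a 6.6-fold higher number from compound 3 to compound 4 (0.82 log units; beyond the scatter)). Activity here therefore depends on the end of the benzyl group and not only on its presence, and of the two groups shown at this place, 4-fluorobenzyl gives the lower number. Compound 4 is not clearly separated from the two compounds without a number, since both floors lie within the scatter (an at least 1.9-fold lower number from compound 1 to compound 4 (0.29 log units; that floor lies within the scatter) and an at least 1.9-fold lower number from compound 2 to compound 4 (0.29 log units; that floor lies within the scatter)), and both comparisons rest on a limit: the limit of > 10000 nM in this assay, at which 2 of the 4 values shown sit.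

Two groups at this place do not separate the effect of the added oxygen from that of the extra heavy atoms, so no cause for the step can be read. On these data alone, how hydrogen, chloro, methoxy, trifluoromethoxy or a nitrile on the same carbon would read in this assay remains open, as does whether any group there gives a lower number than compound 3 (760 nM).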